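Ethyl in place of hydrogen on the carboxy group

The source may report more compounds than this note shows. Statements on the series, on what has been measured and on what is new or still open speak of the compounds shown alone.

- compound 1 `CCOC(=O)/C=C/c1ccc(OC)c(OC(=O)c2nc(C)c(C)nc2C)c1`: 143000 nM
- compound 2 `Cc1nc(C)c(C(=O)Oc2cccc(/C=C/C(=O)O)c2)nc1C`: 26400 nM

In a functional assay on a cell-free system (Platelet, plasma, Oryctolagus cuniculus) for inhibition, with a stated time of 5 min, at 37 degrees C (on this read-out higher numbers stand for weaker inhibition and lower numbers for stronger inhibition), compound 2 gives the lower of the two numbers, 26400 nM, and its gap to compound 1 lies beyond the scatter. Compound 3 `CCOC(=O)/C=C/c1cccc(OC(=O)c2nc(C)c(C)nc2C)c1` has ethyl in place of hydrogen on an oxygen next to a carbonyl group. For the measured compounds named here, no measured step isolates this change. Compound 1, which also carries ethoxycarbonyl, stands at 143000 nM, so a moderate move towards weaker inhibition is expected. The expected size is a 2.8-fold higher number from compound 2 to compound 3 (0.45 log units; beyond the scatter). Compound 3 is estimated at 75000 nM, with an expected range of 25000 nM to 220000 nM.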

Compound 3, half-maximal inhibitory concentration: 35800 nM
Compound 3: middle estimate off by 2.1-fold (0.32 log units), on the high side; the measured number falls inside the stated range.
By their numbers in this assay, from the lowest: compounds 2 and 3 (each within the scatter of the next); then compound 1.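

In this assay carboxy to ethoxycarbonyl reads as a 1.4-fold higher number from compound 2 to compound 3 (0.13 log units; within the scatter) and so does not separate the two compounds. Hydrogen in place of methoxy on an aromatic carbon reads as a 4.0-fold lower number from compound 1 to compound 3 (0.60 log units; beyond the scatter) and is the first single change in the series to lie beyond the scatter. Nothing at hand accounts for either step.

Open, on these data alone, is whether a longer chain such as butyl, or an amide in place of the ethyl ester, reads the same. Also open, as far as these compounds go, is whether methoxy gives a similar step when the carboxy group is present instead of ethoxycarbonyl.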